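The source may report more compounds than this note shows. Statements on the series, on what has been measured and on what is new or still open speak of the compounds shown alone.

Three compounds have been measured so far:
Compound 1, `CC(=O)OC/C1=C/C[C@](C)(CCC=C(C)C)/C=C/[C@@H](OC(=O)C=C(C)C)[C@](C)(O)/C=C/C1=O`, gives 2950 nM in a functional assay on HL-60 cells (Homo sapiens) for antiproliferative activity, read by MTT assay, with a stated time of 48 h; on this read-out higher numbers stand for weaker inhibition and lower numbers for stronger inhibition.
Compound 2, `CCN(CC)C/C1=C/C[C@](C)(CCC=C(C)C)/C=C/[C@@H](OC(=O)C=C(C)C)[C@](C)(O)/C=C/C1=O`, gives 140 nM.
Compound 3, `CC(C)=CCC[C@]1(C)/C=C/[C@@H](OC(=O)C=C(C)C)[C@](C)(O)/C=C/C(=O)/C(CN=[N+]=[N-])=C\C1`, gives 910 nM.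

Among these three, compound 1 has the highest number, so it is the weakest inhibitor of the set. Its nearest neighbour is compound 3, reached by a 3.2-fold lower number from compound 1 to compound 3 (0.51 log units; beyond the scatter), and the furthest is compound 2, reached by a 21-fold lower number from compound 1 to compound 2 (1.32 log units; beyond the scatter).

The unmeasured compound 4, `CC(C)=CCC[C@]1(C)/C=C/[C@@H](OC(=O)C=C(C)C)[C@](C)(O)/C=C/C(=O)/C(Cn2cc(CO)nn2)=C\C1`, differs from compound 1 in one place: 4-(hydroxymethyl)-1H-1,2,3-triazol-1-yl in place of acetoxy on a saturated chain carbon bound to a double-bonded ring carbon.

Both measured steps that start from compound 1 bear on this change, since each also swapped out the acetoxy at that same place. Each of them gave a lower number beyond the usual scatter, one large and one modest. Given that, compound 4 is expected to give a lower number than compound 1 in this assay, most likely of a size between the two measured steps, as a 3.7-fold lower number from compound 1 to compound 4 (0.57 log units; beyond the scatter). Compound 4 is therefore estimated at 800 nM, with a range from 250 nM to 2500 nM.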

Compound 4, half-maximal inhibitory concentration: 3200 nM
For compound 4 the middle estimate is 4.0-fold (0.60 log units) below the measured one; the whole stated range lies below it.
By their numbers in this assay, from the lowest: compound 2; then compound 3; then compounds 1 and 4 (each within the scatter of the next).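

In this assay, swapping out the acetoxy at this place does not by itself change the read-out: 4-(hydroxymethyl)-1H-1,2,3-triazol-1-yl gives a 1.1-fold higher number from compound 1 to compound 4 (0.04 log units; within the scatter), whereas the two earlier replacements both gave lower numbers beyond the scatter. Against those replacements on the same carbon, the new group gives a 3.5-fold higher number from compound 3 to compound 4 (0.55 log units; beyond the scatter) and a 23-fold higher number from compound 2 to compound 4 (1.36 log units; beyond the scatter), so the identity of the entering group matters here, and replacing acetoxy is not enough to lower the number. Nothing available here gives a reason for these differences.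

The compounds shown cannot separate the five-membered ring of the new group from its hydroxymethyl, and a plain 1H-1,2,3-triazol-1-yl or a triazolyl group carrying phenyl in place of hydroxymethyl would speak to that. They also leave open whether the low number of compound 2 belongs to diethylamino alone or extends to other amines, such as dimethylamino or morpholine, on the same carbon.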